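A few compounds are considered here, and "the series" means these few. Any claim that something is new, unique, unknown or untested is made for them only; others in the source may bear on it.

Measured compounds in a functional assay on OVCAR-8 cells (Homo sapiens) for antiproliferative activity; a higher number here means a weaker inhibitor, a lower number a stronger inhibitor:
- compound 1, `Cn1ncc(Cl)c1-c1cc(C(=O)N[C@@H]2CN[C@H](CCn3cncn3)C[C@H]2c2ccc(Cl)c(Cl)c2)oc1Cl`, gives 1560 nM
- compound 2, `Cn1ncc(Cl)c1-c1cc(C(=O)N[C@H]2CNCC[C@@H]2c2ccc(C(F)(F)F)cc2)oc1Cl`, gives 900 nM
- compound 3, `CC(=O)OCC[C@@H]1C[C@@H](c2ccc(F)c(F)c2)[C@H](NC(=O)c2cc(-c3c(Cl)cnn3C)c(Cl)o2)CN1`, gives 4960 nM

On these three numbers compound 1 stands second highest. Its nearest neighbour is compound 2, whose number is lower but lies within the usual scatter, so the two cannot be ordered. Compound 3 is furthest away, with a higher number beyond the scatter. Going by the values given here, no pair of measured compounds differs in a single place, so no isolated step is available from the data themselves.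

Compound 4, `Cn1ncc(Cl)c1-c1cc(C(=O)N[C@@H]2CN[C@H](CC(=O)NCC(O)CO)C[C@H]2c2ccc(Cl)c(Cl)c2)oc1Cl`, is derived from compound 1 by the change ((2,3-dihydroxypropyl)carbamoyl in place of (1H-1,2,4-triazol-1-yl)methyl on a saturated chain carbon bound to a saturated ring carbon). Nothing comparable has been measured in this set; the change sits on the saturated chain carbon bound to a saturated ring carbon, away from the shared core. The expectation for this assay is a step from compound 1 to compound 4 of modest size, a 1.2-fold higher number from compound 1 to compound 4 (0.09 log units; within the scatter), towards a somewhat higher number but not clearly beyond the scatter. Compound 4 is therefore estimated at 1900 nM, with a range of 700 nM to 5500 nM.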

Compound 4, half-maximal inhibitory concentration: 5900 nM
Beside the measured number, compound 4's estimate is 3.1-fold (0.49 log units) below it; measured number above the stated range.
By their numbers in this assay, from the lowest: compounds 2 and 1 (each within the scatter of the next); then compounds 3 and 4 (each within the scatter of the next).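

In this assay, going by these compounds alone, the exchange of (1H-1,2,4-triazol-1-yl)methyl for (2,3-dihydroxypropyl)carbamoyl on a saturated chain carbon bound to a saturated ring carbon gives a 3.8-fold higher number from compound 1 to compound 4 (0.58 log units; beyond the scatter) and so provides the first single-place step in the set. The earlier compounds shown here differed in more than one place and could not show that this position responds to its substituent; here the response lies beyond the scatter. No measurement at hand accounts for the step.

Still open, from the compounds shown here alone, is which part of the change carries the step, since the departure of the triazole ring, the entry of the carbamoyl and the entry of the hydroxyl groups all occur together. A simple methyl amide, a carboxylic acid or a primary amine on the same chain would help separate these parts.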